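A few compounds are considered here, and "the series" means these few. Any claim that something is new, unique, unknown or untested is made for them only; others in the source may bear on it.

Measured compounds in a functional assay on HCT-15 cells (Homo sapiens) for cytotoxicity, read by CCK-8 assay and cell counting, with a stated time of 2 days; a higher number here means a weaker inhibitor, a lower number a stronger inhibitor:
compound 1 `Oc1ccc(-c2cc(-c3ccc(Cl)cc3)nc(-c3ccsc3)c2)cc1` gives 6240 nM
compound 2 `Oc1ccc(-c2cc(-c3ccsc3)nc(-c3ccccc3Cl)c2)cc1` gives 5830 nM

Compound 1 shows the higher of these two numbers, but its nearest neighbour is compound 2, and the step of a 1.1-fold lower number from compound 1 to compound 2 (0.03 log units; within the scatter) lies within the scatter, so the two compounds cannot be told apart on this evidence. That single known step exchanges 2-chlorophenyl for 4-chlorophenyl on an aromatic carbon.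

Compound 3 `Oc1ccc(-c2cc(-c3ccc(Cl)cc3)nc(-c3ccco3)c2)cc1` has not yet been measured. It differs from compound 1 by furan-2-yl in place of thiophen-3-yl on an aromatic carbon. Going by the values given here, no measured step touches this part of the shared core: the only step known, from compound 1 to compound 2, concerns a different group and was itself within the scatter. There is thus no basis for expecting a shift beyond the scatter in this assay in either direction. For compound 3 the expected step of a 1.0-fold lower number from compound 1 to compound 3 (0.02 log units; within the scatter) is accordingly small. Compound 3 is estimated to give about 6000 nM, with a range from 2500 nM to 15000 nM.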

Compound 3, half-maximal inhibitory concentration: 7020 nM
Compound 3: middle estimate off by 1.2-fold (0.07 log units), on the low side, within the range that was stated.
By their numbers in this assay, from the lowest: compounds 2, 1 and 3 (each within the scatter of the next).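

In this assay, placing furan-2-yl instead of thiophen-3-yl on the aromatic carbon next to the ring nitrogen gives a 1.1-fold higher number from compound 1 to compound 3 (0.05 log units; within the scatter), so compound 1 and compound 3 cannot be told apart. Going by these compounds alone, compounds 1 and 2 differed only in the chlorophenyl group, so this pair adds the first reading at this position: here, exchanging one five-membered aromatic ring with 1 hetero atom for another, with sulfur replaced by oxygen, produces no shift that can be distinguished from the scatter. No measurement shown explains this result.

This single pair says nothing about groups of a different kind at this position, such as a simple amine, a carboxylic acid or a short alkyl chain. It also leaves open whether furan-2-yl would behave the same way alongside the 2-chlorophenyl group of compound 2.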